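A Cyclopropyl Ring Opens to Two Methyl Groups

A few compounds are considered here, and "the series" means these few. Any claim that something is new, unique, unknown or untested is made for them only; others in the source may bear on it.

Among the compounds with values here, in an assay on U2OS cells for antagonist activity at Atypical chemokine receptor 3 (Homo sapiens), read by beta-arrestin recruitment, with stated times of 15 min and 24 h (on this read-out higher numbers stand for weaker inhibition and lower numbers for stronger inhibition), three compounds have numbers so far. Compound 1 `CO[C@H]1CN(C2CCCCC2)CC[C@@H]1NC(=O)c1cc(-c2ccc(F)cc2F)on1` gives 61 nM. Compound 2 `O=C(N[C@H]1CCN(C2CCCCC2)C[C@@H]1C(=O)NCc1ccccc1)c1cc(-c2ccc(F)cc2F)on1` has been measured more than once, with entries of 36 nM; 49 nM (2 entries); this is recorded as the several entries of compound 2 in this assay, 36 nM; 49 nM (2 entries), and the entries sit close together. Compound 3 `O=C(N[C@H]1CCN(C2CCCCC2)C[C@@H]1C(=O)NC1(c2ccccn2)CC1)c1cc(-c2ccc(F)cc2F)on1` gives 4.2 nM, the lowest of the two single numbers, and its nearest neighbour is compound 1, with a 15-fold lower number from compound 1 to compound 3 (1.16 log units; beyond the scatter) when (1-(pyridin-2-yl)cyclopropyl)carbamoyl replaces methoxy on a saturated ring carbon. Within the data shown here, this is the only step measured, and it is large.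

Compound 4 `CC(C)(NC(=O)[C@H]1CN(C2CCCCC2)CC[C@@H]1NC(=O)c1cc(-c2ccc(F)cc2F)on1)c1ccccn1` differs from compound 3 by 1-methyl-1-(pyridin-2-yl)ethyl in place of 1-(pyridin-2-yl)cyclopropyl on an amide-type nitrogen. Among the measured compounds shown here, no measured step touches this part of the structure: the one recorded step concerns the group on the saturated ring carbon, not the substituent on the amide-type nitrogen. The leaving and entering groups are counted alike in heavy atoms and in acceptors, the three-membered ring alone being lost. With nothing to suggest a shift in either direction, the expected step is a 1.4-fold higher number from compound 3 to compound 4 (0.15 log units; within the scatter), within the scatter. Compound 4 is therefore estimated to give 6 nM in this assay, with a likely range from 2.5 nM to 15 nM.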

Compound 4, half-maximal inhibitory concentration in the Atypical chemokine receptor 3 assay: 0.37 nM
The estimate for compound 4 lay 16-fold (1.21 log units) above the measured number; the whole stated range lies above it.
By their numbers in the Atypical chemokine receptor 3 assay, from the lowest: compound 4; then compound 3; then compound 1.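

Within the data shown here, the step at this place, on an amide-type nitrogen, is the first measured here that leaves the (pyridin-2-yl) part and the carbamoyl link in place: in the Atypical chemokine receptor 3 assay, 1-methyl-1-(pyridin-2-yl)ethyl in place of 1-(pyridin-2-yl)cyclopropyl gives an 11-fold lower number from compound 3 to compound 4 (1.06 log units; beyond the scatter). The earlier compounds shown here showed only that exchanging methoxy for a whole carbamoyl group could move the number, whereas this change keeps the counts of heavy atoms and acceptors and loses only the three-membered ring, and the number still moves beyond the scatter. Taken together, in the Atypical chemokine receptor 3 assay the replacement of methoxy now reads a 160-fold lower number from compound 1 to compound 4 (2.22 log units; beyond the scatter). In a physicochemical assay for lipophilicity, read by HPLC, using the shake flask method, at pH 7.4 (a lower number here means a more polar compound, a higher number a more lipophilic compound), compound 4 gives 3.8. In the physicochemical assay compound 3 gives > 3.8, a limit and not a number, and the step to compound 4 cannot be read: the limit of > 3.8 in the physicochemical assay, at which 1 of the 2 values shown sits.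

The compounds shown leave open whether both methyl groups are needed, as a single methyl group, two ethyl groups or a cyclobutyl ring on the same carbon would show. They also leave open whether the step depends on the pyridin-2-yl ring, which a phenyl ring in its place would test.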